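Trading methoxy for 4-methylpiperazin-1-yl at a limit

A few compounds are considered here, and "the series" means these few. Any claim that something is new, unique, unknown or untested is made for them only; others in the source may bear on it.

Compound 1 (`COc1ccnc(Nc2cc3[nH]c(-c4cccc(C(F)(F)F)c4)nc3cn2)c1`), compound 2 (`COc1ccc(Nc2cc3[nH]c(-c4cccc(C(F)(F)F)c4)nc3cn2)nc1`) and compound 3 (`FC(F)(F)c1cccc(-c2nc3cnc(Nc4ncccn4)cc3[nH]2)c1`) share one core and differ in the aromatic group on a nitrogen. In a physicochemical assay for solubility, using the shake flask method, in phosphate buffer, measured as kinetic solubility, with a stated time of 20 h, at pH 6.5 (on this read-out lower numbers stand for lower solubility and higher numbers for higher solubility), compound 1 gives < 5000 nM, which is a limit and not a number. Compound 2 gives < 5000 nM, also a limit. Compound 3 gives < 5000 nM, again a limit. Compound 2 therefore has no number of its own, and it shares its position with the other two: the limit of < 5000 nM in this assay, at which 3 of the 3 values shown sit.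

The measured steps are a step that the two limits leave unreadable from compound 1 to compound 2, a step that the two limits leave unreadable from compound 1 to compound 3 and a step that the two limits leave unreadable from compound 2 to compound 3. All of them change the group on that nitrogen, and none offers a size to carry forward.

Compound 4 (`CN1CCN(c2ccc(Nc3cc4[nH]c(-c5cccc(C(F)(F)F)c5)nc4cn3)nc2)CC1`) departs from compound 2 in one place: 4-methylpiperazin-1-yl in place of methoxy on an aromatic carbon. This puts 4-methylpiperazin-1-yl in place of methoxy on an aromatic carbon. With no readable step to lean on, the expectation rests on this structural change alone, and it is correspondingly loose. The expected step, upward in this assay and of uncertain size, is an at least 2.4-fold higher number from compound 2 to compound 4 (0.38 log units; beyond the scatter). For compound 4 the estimated value is 12000 nM, with an expected range of 3000 nM to 60000 nM.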

Compound 4, solubility: 66000 nM
Compound 4: middle estimate off by 5.5-fold (0.74 log units), on the low side; measured number above the stated range.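

Among the compounds shown here, replacing methoxy with 4-methylpiperazin-1-yl, on an aromatic carbon of a six-membered aromatic ring with 1 nitrogen and para to a large group, gives in this assay an at least 13-fold higher number from compound 2 to compound 4 (1.12 log units; beyond the scatter), and this change to the substituent on that ring gives the first step with a readable size. The steps among compound 1, compound 2 and compound 3 cannot be read, so swapping the aromatic group on the nitrogen gave no size for comparison, whereas this position is now shown to be able to move the read-out well beyond the scatter. Compound 4 is also the first compound here with a number of its own, while compound 2 still has only a limit, which it shares with compound 1 and compound 3: the limit of < 5000 nM in this assay, at which 3 of the 4 values shown sit.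

On these data alone, what remains open is whether the whole 4-methylpiperazin-1-yl group is needed at this position, or whether a morpholine ring, an unmethylated piperazine or an open-chain dimethylamino group would give a comparable number. As far as these compounds go, it is also open whether the same exchange would give a step of similar size on the aromatic groups of compound 1, which carries its methoxy at a different place.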